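Spirooxindole Quinoxaline Series: Aryltriazole Swap Ahead of Measurement

A few compounds are considered here, and "the series" means these few. Any claim that something is new, unique, unknown or untested is made for them only; others in the source may bear on it.

Measured compounds:
- compound 1, `N#CC1=C(N)Oc2c(c3nc4ccccc4nc3c3ccccc23)C12C(=O)N(Cc1cnnn1-c1ccc([N+](=O)[O-])cc1)c1ccccc12`: > 50000 nM
- compound 2, `Cc1ccccc1-n1nncc1CN1C(=O)C2(C(C#N)=C(N)Oc3c(N)cc4nc5ccccc5nc4c32)c2ccccc21`: 31700 nM

For the measured compounds named here, both compounds have been tested in a functional assay on A549 cells (Homo sapiens) for antiproliferative activity, read by MTT assay, with a stated time of 48 h; a lower number here means a stronger inhibitor, a higher number a weaker inhibitor. Compound 1 returns only a limit of the assay, > 50000 nM, so no number is available for it; this is the situation described by the limit of > 50000 nM in this assay, at which 1 of the 2 values shown sits. Going by the values given here, compound 2 gives 31700 nM in this assay, the only actual number in the set. It therefore stands as the sole anchor, and weakly active at that.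

The compound not yet measured is compound 3, `N#CC1=C(N)Oc2c(N)cc3nc4ccccc4nc3c2C12C(=O)N(Cc1cnnn1-c1ccc([N+](=O)[O-])cc1)c1ccccc12`. Relative to compound 2 the change is 4-nitrophenyl in place of 2-methylphenyl on an aromatic nitrogen. The rest of the shared core, including the amino group on the core and the nitrile, is unchanged. Among the compounds with values here, no measured pair in the set isolates this swap, so its effect in this assay is not known from the data.

Given the weak starting point of compound 2, the step is expected to be small and, if anything, toward weaker inhibition. Compound 3 is estimated at 40000 nM, with a range of 15000 nM to 100000 nM. The expected step of a 1.3-fold higher number from compound 2 to compound 3 (0.10 log units; within the scatter) lies within the usual scatter of such measurements.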

Compound 3, half-maximal inhibitory concentration: > 50000 nM
Compound 3 gave a limit, no number (the forecaster's own chance of this, stated with the estimate: 45%); middle value at least 1.2-fold (0.09 log units) away from the limit.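

In this assay compound 3 gives > 50000 nM, which is a limit of the assay and not a number. Placing 4-nitrophenyl in place of 2-methylphenyl on the aromatic nitrogen of the five-membered aromatic ring with 3 nitrogen gives the first direct reading at this position, an at least 1.5-fold higher number from compound 2 to compound 3 (0.19 log units; that floor lies within the scatter). That reading is only a floor and does not establish a difference beyond the usual scatter, although it shows no gain from the 4-nitrophenyl group, and the set now stands as follows: the limit of > 50000 nM in this assay, at which 2 of the 3 values shown sit.

For the compounds shown here, the true size of the step remains unknown, and the only number in the set still belongs to the 2-methylphenyl group of compound 2, at 31700 nM. Open questions are whether an unsubstituted phenyl, a benzyl group or a phenyl bearing an amine or a carboxylic acid at this position would give a number clearly lower than that of compound 2, and whether any such group would yield a measurable value rather than a limit.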